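Efficacy of isoxazole ethers: from compound 3 to compound 4

This account rests on a few compounds, and the source may have more. Where it says the series, first, only, none or still open, it means among the compounds named here.

Compound 1 `Cc1cc(OCc2c(-c3c(Cl)cccc3Cl)noc2C(C)C)nc2ccccc12`: 104%
Compound 2 `Cc1cc(C(F)(F)F)cc(OCc2c(-c3c(Cl)cccc3Cl)noc2C(C)C)n1`: 98%
Compound 3 `CC(C)c1onc(-c2c(Cl)cccc2Cl)c1COc1ccc(N(C)Cc2ccc(CCC(=O)O)cc2)c(C(F)(F)F)n1`: 96%

Of the compounds shown here, three sharing the same core have been measured in an assay on isolated protein for agonist activity at Bile acid receptor (Homo sapiens), read by FRET; on this read-out lower numbers stand for smaller maximal responses and higher numbers for larger maximal responses. Compound 1 gives 104%, compound 2 gives 98% and compound 3 gives 96%. Compound 3 has the lowest of the three numbers, but its distance to compound 2 and to compound 1 both lie within the usual scatter, so the three are not distinguishable from one another on this read-out; all reach a maximal response close to the reference.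

Compound 4 `CC(C)c1onc(-c2c(Cl)cccc2Cl)c1COc1ccc(N(C)Cc2ccc(OCCO)cc2)c(C(F)(F)F)n1` has not yet been measured. It differs from compound 3 in one place: 2-hydroxyethoxy in place of 2-carboxyethyl on an aromatic carbon. The 2-carboxyethyl group leaves and a 2-hydroxyethoxy group enters on the same aromatic carbon, para to a large group, so that the 4-(2-carboxyethyl)benzyl becomes a 4-(2-hydroxyethoxy)benzyl.

Going by the values given here, no step between two measured compounds is available to calibrate this change. Since compounds 1, 2 and 3 all lie within the scatter of each other despite differing on the ether side, the step from compound 3 to compound 4 in this assay is expected to be no more than the scatter, with no clear direction: a number 1 percentage points lower from compound 3 to compound 4 (within the scatter). Compound 4 is therefore estimated to give 95%, with a range from 80% to 108%.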

Compound 4, largest response reached (reported as efficacy), in percent of the reference or control that the assay uses: 87%
Estimate against measurement, compound 4: 8 percentage points above; the range from low to high includes it.
By their numbers in this assay, from the lowest: compounds 4, 3, 2 and 1 (each within the scatter of the next, the first and the last beyond it).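

In this assay, 2-hydroxyethoxy in place of 2-carboxyethyl, on an aromatic carbon para to a large group, gives a number 9 percentage points lower from compound 3 to compound 4 (within the scatter). Going by these compounds alone, this is the first step read at a single place, and it shows that this position can exchange the 4-(2-carboxyethyl)benzyl for the 4-(2-hydroxyethoxy)benzyl without a step beyond the scatter, so the carboxylic acid of compound 3 is not needed at this position for compound 4 to give a maximal response that cannot be told apart from that of compound 3. Nothing at hand offers an explanation for the size of this step.

On these data alone, whether an amine, a longer chain ending in a hydroxyl, or a carboxylic acid joined through an ether oxygen on the same aromatic carbon would also stay within the scatter of compound 3 remains open, as does the outcome with a plain benzyl carrying only hydrogen there. The compounds shown also give only a maximal response, so they leave open how this change bears on the concentration at which that response is reached.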